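Moving the Methyl Group on the Outer Ring

The source may report more compounds than this note shows. Statements on the series, on what has been measured and on what is new or still open speak of the compounds shown alone.

Among the compounds with values here, compound 3 `Cc1cccc(Nc2nc3nonc3nc2Nc2ccccc2F)c1` gives 1500 nM in an assay on mitochondria from L6 cells (Rattus norvegicus) for activation, with a stated time of 90 min (a lower number here means that less compound is needed, a higher number that more compound is needed for the effect), the higher of the two numbers measured so far. Within the data shown here, compound 2 `Fc1ccccc1Nc1nc2nonc2nc1Nc1cccc(F)c1F` gives 500 nM in this assay, and the step of a 3.0-fold higher number from compound 2 to compound 3 (0.48 log units; beyond the scatter) is the only measured step between neighbouring compounds. Compound 1 `Cc1ccc(Nc2nc3nonc3nc2Nc2ccc(C)cc2)cc1` reaches only the limit > 20000 nM in this assay. Compound 4 `Cc1ccc(Nc2nc3nonc3nc2Nc2ccccc2F)cc1` differs from compound 3 in one place: 4-methylphenyl in place of 3-methylphenyl on a nitrogen on an aromatic ring. Among the measured compounds shown here, no measured step covers this exact change. Compound 1, which carries 4-methylphenyl on both nitrogens, sits at the limit (the limit of > 20000 nM in this assay, at which 1 of the 3 values shown sits), which points toward a higher number once a 4-methylphenyl is present, although compound 1 also lacks the 2-fluorophenyl that compound 4 keeps. A modest rise is therefore expected, a 2.7-fold higher number from compound 3 to compound 4 (0.43 log units; beyond the scatter). Compound 4 is estimated at 4000 nM, between 1500 nM and 12000 nM.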

Compound 4, half-maximal effective concentration: 2100 nM
The estimate for compound 4 lay 1.9-fold (0.28 log units) above the measured number, within the range that was stated.
By their numbers in this assay, from the lowest: compound 2; then compounds 3 and 4 (each within the scatter of the next). At a limit, above all of these: compound 1.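

In this assay the swap of 3-methylphenyl for 4-methylphenyl gives a 1.4-fold higher number from compound 3 to compound 4 (0.15 log units; within the scatter) and so cannot be told apart from repeat measurements. The gap to the 2,3-difluorophenyl of compound 2 remains, with a 4.2-fold higher number from compound 2 to compound 4 (0.62 log units; beyond the scatter) now seen for 4-methylphenyl as well. Starting from a value that is a limit, an at least 9.5-fold lower number from compound 1 to compound 4 (0.97 log units; beyond the scatter) shows that one 4-methylphenyl does not by itself put a compound at that limit.

From the compounds shown here alone, whether an amine or a carboxylic acid in place of the methyl group would shift the number stays open, as does the result of pairing 4-methylphenyl with 2,3-difluorophenyl on the shared core.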